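Three Analogues and a Fluoro Addition

This account rests on a few compounds, and the source may have more. Where it says the series, first, only, none or still open, it means among the compounds named here.

Measured so far:
Compound 1, `Fc1ccc(Oc2[nH]cnc3ncnc2-3)cc1` — 0%
Compound 2, `Fc1ccc(Sc2[nH]cnc3nccc2-3)cc1` — 3%
Compound 3, `c1ccc(Cc2[nH]cnc3ncnc2-3)cc1` — 2%

In an assay on isolated protein for inhibition of Ca2+/calmodulin-dependent protein kinase II (CaM kinase II) (Rattus norvegicus), tested at 30 uM (a higher number here means more inhibition at the concentration tested (going by the name of the read-out), a lower number less inhibition), compound 1 gives 0%. Compound 2 gives 3% in this assay, and compound 3 gives 2%. For the measured compounds named here, all three numbers lie within the scatter of one another, so no compound can be called stronger or weaker than another; compound 3 stands second among the three, but its nearest neighbour, compound 2, and its furthest, compound 1, both sit within the usual spread of repeated measurements.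

Compound 4, `Fc1ccc(Cc2[nH]cnc3ncnc2-3)cc1`, has not yet been measured. It differs from compound 3 by fluoro in place of hydrogen on an aromatic carbon. Nothing in the measured set speaks for a step beyond the scatter in this assay: compound 1 already carries fluoro on its aromatic ring and gives 0%, no higher than the others. Compound 4 is therefore expected to give 3%, in a range from 0% to 12%. The step from compound 3 to compound 4 is estimated at a number 1 percentage points higher from compound 3 to compound 4 (within the scatter), that is, no change beyond the scatter.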

Compound 4, a percentage reported as inhibition, at one concentration (the size of the read-out at that concentration, not a potency): 8%
For compound 4 the middle estimate is 5 percentage points below the measured one, and the stated range covers the measured number.
By their numbers in this assay, from the lowest: compounds 1, 3, 2 and 4 (each within the scatter of the next).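

In this assay, fluoro in place of hydrogen on an aromatic carbon, para to a large group, gives a number 6 percentage points higher from compound 3 to compound 4 (within the scatter). For the compounds shown here, this is the first step in the set that can be read between two compounds differing in one place, and it shows that this change at this position stays within the usual scatter, with compound 4 at 8% at the one concentration tested. Nothing available on the compounds accounts for this result.

The compounds shown leave open whether an amine, a carboxylic acid, a methoxy group or a trifluoromethyl group at this same carbon would give a step beyond the scatter. They also leave open whether chloro there would read any differently from fluoro.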